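The source may hold more compounds than are shown below. What is called first, only, known or untested is meant among the compounds shown, and "the series" means these compounds.

Of the compounds shown here, two have numbers so far in a functional assay on NCI-H460 cells (Homo sapiens) for inhibition, with a stated time of 72 h; a lower number here means a stronger inhibitor, a higher number a weaker inhibitor. Compound 1 (`COc1ccc(S(=O)(=O)N2CCc3cccc(-c4ccc(N(C)C)cc4)c32)cc1`) gives 556 nM, the higher of the two numbers, which makes it the weaker inhibitor of the pair. Compound 2 (`COc1ccc(S(=O)(=O)n2ccc3cccc(-c4ccc(F)cc4)c32)cc1`) gives 212 nM, and this gap lies beyond the usual scatter of repeated measurements. The two compounds differ in more than one place, so the gap cannot be pinned on any single group.

Compound 3 (`COc1ccc(S(=O)(=O)N2CCc3cccc(-c4ccccc4)c32)cc1`) has not yet been measured in this assay. It keeps the core of compound 1 with one change, hydrogen in place of dimethylamino on an aromatic carbon, which turns 4-(dimethylamino)phenyl into phenyl. For the measured compounds named here, no measured pair shows this change alone, so any expectation is loose. It leans on compound 2, which has no dimethylamino group and gives 212 nM. The estimated step of a 1.9-fold lower number from compound 1 to compound 3 (0.27 log units; within the scatter) is a modest one toward a lower number, close to the edge of the usual scatter. For compound 3 the expected value is 300 nM, with an estimated range of 90 nM to 1000 nM.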

Compound 3, half-maximal inhibitory concentration: 213 nM
The estimate for compound 3 lay 1.4-fold (0.15 log units) above the measured number, and the stated range covers the measured number.
By their numbers in this assay, from the lowest: compounds 2 and 3 (each within the scatter of the next); then compound 1.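

For the compounds shown here, for the first time a single change can be read on its own: in this assay, hydrogen in place of dimethylamino on an aromatic carbon, which turns 4-(dimethylamino)phenyl into phenyl, brings a 2.6-fold lower number from compound 1 to compound 3 (0.42 log units; beyond the scatter). At this position, para to a large group, the dimethylamino group is therefore not needed for inhibition in this cell assay, since compound 3, with plain phenyl, gives 213 nM and is the stronger inhibitor of this pair. Nothing available explains why the number moves with this change.

As far as these compounds go, this is one pair at one position, so it remains open whether a carboxylic acid, a morpholine ring or a longer amine chain in the same place would behave like hydrogen or like dimethylamino. Also open, from the compounds shown here alone, is what the fluorine and the different core each contribute in compound 2, which differs from compound 3 in more than one place, so that their closeness in number cannot be credited to either feature.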